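The compounds below may be only part of what the source reports. "The series", "measured", "known", "first", "only" and "open" are said of these compounds alone.

Measured compounds:
Compound 1, `COc1cc(NC(C)CCCNC(=O)/C=C/c2ccc(OC)c(OC)c2)c2ncccc2c1`: > 220000 nM
Compound 2, `COc1ccc(/C=C/C(=O)NNC(=O)NCCCC(C)Nc2cc(OC)cc3cccnc23)cc1`: 3600 nM

In an ADME assay on L6 cells (Rattus norvegicus) for cytotoxicity, read by resazurin assay, with a stated time of 70 h (on this read-out lower numbers stand for stronger inhibition and higher numbers for weaker inhibition), compound 2 gives 3600 nM, which is the only numerical result in this set. Compound 1 reaches only a limit of the assay in this assay, > 220000 nM, so it gives no number to compare with; this is described by the limit of > 220000 nM in this assay, at which 1 of the 2 values shown sits. Compound 3, `COc1cc(NC(C)CCCNC(=O)NNC(=O)Nc2cccc(Cl)c2)c2ncccc2c1`, has not yet been measured in this assay. It differs from compound 2 in one place: (3-chlorophenyl)amino in place of 2-(4-methoxyphenyl)ethenyl on a carbonyl carbon. Among the compounds with values here, because no step between two measured compounds is available, there is nothing to calibrate this change against, and the expectation rests on the single value of compound 2 and on the nature of the change itself. The expectation is a moderate step towards weaker inhibition in this assay, somewhat beyond the usual scatter, with considerable uncertainty in both directions. Compound 3 is therefore estimated at 10000 nM in this assay, within a range of 2500 nM to 60000 nM. The expected step is a 2.8-fold higher number from compound 2 to compound 3 (0.44 log units; beyond the scatter).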

Compound 3, half-maximal inhibitory concentration: 58600 nM
For compound 3 the middle estimate is 5.9-fold (0.77 log units) below the measured one; the range from low to high includes it.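

In this assay, 2-(4-methoxyphenyl)ethenyl leaves and (3-chlorophenyl)amino enters at a carbonyl carbon bonded to an amide-type nitrogen, which gives a 16-fold higher number from compound 2 to compound 3 (1.21 log units; beyond the scatter). Within the data shown here, this is the first step in the set that can be read between two measured compounds, and it shows that the group on this carbonyl carbon matters: the change is large and lies clearly beyond the usual scatter of repeated measurements. Compound 3 still gives a real number rather than a limit, so this change leaves it within the range that can be measured, whereas one compound in the set does not give a number: the limit of > 220000 nM in this assay, at which 1 of the 3 values shown sits.

The step changes several things at once, including the link to the aromatic ring, with its double bond leaving and an amino nitrogen entering, and the group on that ring, with 4-methoxy giving way to 3-chloro, and one step cannot show which of these drives the shift. From the compounds shown here alone, how a (4-methoxyphenyl)amino group or an unsubstituted phenylamino group would behave on the same carbonyl carbon remains open, and either comparison would help to separate those contributions.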